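This account rests on a few compounds, and the source may have more. Where it says the series, first, only, none or still open, it means among the compounds named here.

Measured in a functional assay on MDA-N cells (Homo sapiens) for inhibition, read by sulforhodamine B assay, with a stated time of 48 h; on this read-out lower numbers stand for stronger inhibition of growth and higher numbers for weaker inhibition of growth:
- Compound 1 `CN(C)/C=C/C(=O)c1nn(-c2ccccc2)c(-c2ccccc2)c1C#N`: 45400 nM
- Compound 2 `Cc1nnc(-c2nn(-c3ccccc3)c(-c3ccccc3)c2C#N)c2cn(-c3ccccc3)nc12`: 38400 nM
- Compound 3 `N#Cc1c(-c2nnc(O)c3nn(-c4ccccc4)cc23)nn(-c2ccccc2)c1-c1ccccc1`: 13800 nM

Of these three, compound 3 has the lowest number in this assay, which makes it the strongest growth inhibitor of the set. Compound 4 `N#Cc1c(-c2nnc(O)c3nn(-c4ccc(Cl)cc4)cc23)nn(-c2ccccc2)c1-c1ccccc1` has not yet been measured. It is compound 3 with one phenyl turned into 4-chlorophenyl, that is, chloro in place of hydrogen on an aromatic carbon.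

Among the compounds with values here, only one measured step links two compounds that differ in a single place: a 2.8-fold lower number from compound 2 to compound 3 (0.44 log units; beyond the scatter). That modest step is a different change, hydroxy in place of methyl on an aromatic carbon, so it gives only a rough idea of how large one small change can be here. Within the data shown here, no measured compound carries a chloro, and the data give no direction for this change. An estimated 1.3-fold lower number from compound 3 to compound 4 (0.10 log units; within the scatter) is therefore expected, with no clear shift beyond the scatter. For compound 4 the expected value is 11000 nM, with an estimated range from 4500 nM to 27000 nM.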

Compound 4, concentration for 50% growth inhibition: > 100000 nM
Compound 4: a limit, no number; the forecaster's own chance of this, stated with the estimate: 5%; middle value at least 9.0-fold (0.95 log units) away from the limit.
By their numbers in this assay, from the lowest: compound 3; then compounds 2 and 1 (each within the scatter of the next). At a limit, above all of these: compound 4.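

Placing a single chloro on this phenyl, para to a large group, weakens growth inhibition in this assay, with an at least 7.2-fold higher number from compound 3 to compound 4 (0.86 log units; beyond the scatter), so this site on the molecule is sensitive to even a one-atom change. The reading for compound 4, > 100000 nM, is a limit of the assay and not a number. Within the data shown here, the only earlier step, a 2.8-fold lower number from compound 2 to compound 3 (0.44 log units; beyond the scatter), involved a different change elsewhere on the molecule and went the opposite way, toward stronger inhibition, so this is the first sign that a small change can cost activity.

On these data alone, it remains open whether a fluoro, a methoxy or an amine at this same place would behave like chloro, or whether the loss is specific to chloro. Also open, as far as these compounds go, is how a chloro would act on either of the other two phenyl groups.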